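The source may report more compounds than this note shows. Statements on the series, on what has been measured and on what is new or still open speak of the compounds shown alone.

Working notes on the cyanoguanidine series in a functional assay on the whole organism (blood, strain Wistar-Okamoto) with Rattus norvegicus as the target, with a stated time of 5 days; on this read-out lower numbers stand for an effect already at smaller amounts and higher numbers for an effect only at larger amounts of compound.

Compound 1 `CCCCC/N=C(\NC#N)Nc1cccnc1` stands as the highest of the two numbers that are known in this assay: in this assay compound 1 gives 20 mg/kg. Its nearest neighbour is compound 3 `CC(/N=C(/NC#N)Nc1cccnc1)C(C)(C)C`, which in this assay gives 1 mg/kg, a gap well beyond the usual scatter. Compound 2 `CCCCC(CC)C/N=C(\NC#N)Nc1cccnc1` yields only a limit of the assay, not a number, > 50 mg/kg; this is the limit of > 50 mg/kg in this assay, at which 1 of the 3 values shown sits.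

The step from compound 1 to compound 4 `CC1(/N=C(\NC#N)Nc2cccnc2)CCC1` is 1-methylcyclobutyl in place of pentyl on a double-bonded nitrogen. For the measured compounds named here, no measured pair in the set shows this change directly, so the size of the step rests on what the neighbours show. Compound 3, with its own compact substituent on the double-bonded nitrogen, sits far below compound 1, while compound 2 reaches only the limit, so the direction is not settled by the chain length alone.

The step of a 5.0-fold lower number from compound 1 to compound 4 (0.70 log units; beyond the scatter) is expected to run towards a lower number, since compound 3 in this assay gives 1 mg/kg. Compound 4 is therefore estimated at 4 mg/kg, with a range of 1 mg/kg to 20 mg/kg.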

Compound 4, minimum effective dose: 50 mg/kg
Compound 4: the middle estimate sits 13-fold (1.10 log units) below what was measured, outside the stated range (above it).
By their numbers in this assay, from the lowest: compound 3; then compound 1; then compound 4.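

For the compounds shown here, at this position, on a double-bonded nitrogen, the swap of pentyl for 1-methylcyclobutyl keeps the heavy-atom count and the all-carbon make-up and adds only the four-membered ring, yet in this assay it gives a step the earlier compounds could not show (a 2.5-fold higher number from compound 1 to compound 4 (0.40 log units; beyond the scatter)). The series therefore does not follow a simple contrast between open chains and shorter, more branched groups at this place: in this assay compound 3 gives 1 mg/kg, while compound 4, which also lacks a straight chain, gives 50 mg/kg. Nothing recorded with the series bears on why the change runs in this direction.

Still open, from the compounds shown here alone, is whether the higher number of compound 4 goes with the four-membered ring itself or with the methyl group on it, which cyclobutyl without the methyl group, or tert-butyl, at the same nitrogen would help to separate. Also open, going by these compounds, is how larger rings such as cyclopentyl or cyclohexyl would read at this position, and whether the low number of compound 3 survives any further change to its substituent.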